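From tert-butoxy to morpholin-4-yl on a carbonyl carbon

The compounds below may be only part of what the source reports. "The series", "measured", "known", "first", "only" and "open" are said of these compounds alone.

In a functional assay on HT-29 cells (Homo sapiens) for antiproliferative activity, read by MTT assay, with a stated time of 72 h (on this read-out lower numbers stand for stronger inhibition and higher numbers for weaker inhibition), compound 1 `C=CC(=O)N(Cc1ccccc1)c1nc(-c2ccccc2)cs1` gives > 30000 nM, which is a limit of the assay and not a number. Compound 2 `C=CC(=O)N(CC(=O)OC(C)(C)C)c1nc(-c2ccccc2)cs1` gives > 30000 nM, also a limit. So compound 2 has no exact value to start from, and the same holds for the only other compound measured: the limit of > 30000 nM in this assay, at which 2 of the 2 values shown sit. Within the data shown here, the one measured step is a step that the two limits leave unreadable from compound 1 to compound 2, so it offers no size to carry forward.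

Compound 3 `C=CC(=O)N(CC(=O)N1CCOCC1)c1nc(-c2ccccc2)cs1` has morpholin-4-yl in place of tert-butoxy on a carbonyl carbon. Among the measured compounds shown here, nothing measured so far points to a gain in this assay, so no clear change in either direction is expected. The expected step is a number no higher from compound 2 to compound 3 (the limit leaves the size open). For compound 3 the estimate is 30000 nM, with an expected range from 10000 nM to 60000 nM.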

Compound 3, half-maximal inhibitory concentration: 13300 nM
Estimate against measurement, compound 3: 2.3-fold (0.35 log units) above; low and high end bracket the measured number.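

Morpholin-4-yl in place of tert-butoxy on a carbonyl carbon gives the first exact number in this assay, which shows that this position can move the read-out beyond the scatter: an at least 2.2-fold lower number from compound 2 to compound 3 (0.35 log units; beyond the scatter). Set against phenyl on a saturated chain carbon bound to an amide-type nitrogen, (morpholin-4-yl)carbonyl also gives a readable change: an at least 2.2-fold lower number from compound 1 to compound 3 (0.35 log units; beyond the scatter). Both steps give only a smallest size and not a full one, since the other two compounds stay at a limit of the assay: the limit of > 30000 nM in this assay, at which 2 of the 3 values shown sit.

The compounds shown leave open whether the whole ring, its oxygen or its nitrogen matters at this carbonyl carbon, and how far the number can fall. A piperidin-1-yl group, a dimethylamino group or a carboxylic acid in the same place would help to separate these possibilities.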